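A few compounds are considered here, and "the series" means these few. Any claim that something is new, unique, unknown or untested is made for them only; others in the source may bear on it.

In an ADME assay on THP-1 cells (Homo sapiens) for cytotoxicity, read by MTT assay, with a stated time of 72 h (on this read-out lower numbers stand for higher toxicity in this test and higher numbers for lower toxicity in this test), compound 3, `COc1ccc(-c2cn(Cc3cc(-c4ccc(OC)c(OC)c4)no3)nn2)cc1`, gives > 500000 nM, which is a limit of the assay and not a number. Compound 2, `COc1ccc(-c2cc(Cn3cc(-c4cc(C)c(C)cc4C)nn3)on2)cc1OC`, gives > 500000 nM, and this too is a limit. Compound 3 therefore stands at the limit of > 500000 nM in this assay, at which 2 of the 3 values shown sit, with no exact value to start from. For compound 1, `FC(F)(F)Oc1ccc(-c2cn(Cc3cc(-c4ccccc4)no3)nn2)cc1`, the entry reads "not determined" (no result reported). It carries a trifluoromethoxy group but offers no measured guide.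

The next molecule is compound 4, `COc1ccc(-c2cc(Cn3cc(-c4ccc(OC(F)(F)F)cc4)nn3)on2)cc1OC`, which differs from compound 3 in one place: trifluoromethyl in place of methyl on an oxygen on an aromatic ring. Trifluoromethyl stands in place of methyl on an oxygen on an aromatic ring, so a methoxy becomes a trifluoromethoxy.

For the measured compounds named here, only one measured step bears on this question, and it involves a different change: a step that the two limits leave unreadable from compound 2 to compound 3. It has no readable size, so it can show neither how large the new step will be nor which way it will go. Its two compounds do share the same limit, however, and that makes the limit the most reasonable starting point.

The expectation is a number no higher from compound 3 to compound 4 (the limit leaves the size open), with no change beyond the usual scatter and no firm direction. For compound 4 the estimated value is 500000 nM, with an expected range from 150000 nM to 1000000 nM.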

Compound 4, half-maximal cytotoxic concentration: 227000 nM
Estimate against measurement, compound 4: 2.2-fold (0.34 log units) above; the measured number falls inside the stated range.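

In this assay, turning a methoxy into a trifluoromethoxy, on an oxygen on an aromatic ring, gives an at least 2.2-fold lower number from compound 3 to compound 4 (0.34 log units; beyond the scatter). Lower numbers here mean higher toxicity in this test, so this one change moves the compound towards higher toxicity, beyond the usual scatter of repeated measurements, which no earlier comparison could show. The earlier step cannot be read, and compound 4 now supplies the only exact number in the set, while the other results shown are either a limit of the assay or no result at all: the limit of > 500000 nM in this assay, at which 2 of the 4 values shown sit.

Going by these compounds, compound 3 carries a limit and not an exact number, so the true size of this step stays open, and it could be larger than the printed minimum. On these data alone, with a single swap at this place, it also stays open whether the shift belongs to the three fluorine atoms in particular, or whether a chlorine atom, an amine, a carboxylic acid or a longer chain on the same aromatic ring would move the number in the same direction.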